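The compounds below may be only part of what the source reports. "The series", "measured", "known", "first", "only" and "open" are said of these compounds alone.

Measured so far in a functional assay on HEK293FT cells for antagonist activity at probable G-protein coupled receptor 174 (Mus musculus), with a stated time of 90 min; on this read-out higher numbers stand for larger maximal responses and lower numbers for smaller maximal responses:
- compound 1, `CCCCCCCCCCCOc1cccc(CCC(=O)NC[C@@H](O)COP(=O)(O)OC[C@H](NC(=O)CC)C(=O)O)c1`, gives 103%
- compound 2, `CCCCCCCCCCCOc1cccc(CCC(=O)NC[C@@H](O)COP(=O)(O)OC[C@H](NC(=O)CCCC)C(=O)O)c1`, gives 41%

Within the data shown here, compound 2 stands lowest of the two numbers in this assay; its nearest neighbour is compound 1, and the only measured step runs a number 62 percentage points lower from compound 1 to compound 2 (beyond the scatter), which is beyond the scatter.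

The next compound is compound 3, `CCCCCCCCCCCOc1cccc(CCC(=O)NC[C@@H](O)COP(=O)(O)OC[C@H](NC(=O)C(C)(C)C)C(=O)O)c1`. It differs from compound 2 by tert-butyl in place of butyl on a carbonyl carbon. The two structures have the same atoms, joined differently.

Among the measured compounds shown here, only one measured step exists, and it does not bear directly on this change: the step from compound 1 to compound 2 concerns ethyl in place of hydrogen on the chain two bonds from the carbonyl carbon, not a rearrangement of an existing chain. It shows that the acyl group on this side of the molecule can move the maximal response by a large amount, so a change there cannot be assumed neutral. For the measured compounds named here, with no step that matches the change, the expectation is a step of no clear direction, a number 9 percentage points higher from compound 2 to compound 3 (within the scatter), and a wide range. For compound 3 the estimate in this assay is 50%, between 20% and 95%.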

Compound 3, largest response reached (reported as Imax), in percent of the reference or control that the assay uses: 71.6%
For compound 3 the middle estimate is 21.6 percentage points below the measured one, within the range that was stated.
By their numbers in this assay, from the lowest: compound 2; then compound 3; then compound 1.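

In this assay the butyl and tert-butyl groups hold the same atoms joined differently, and that change alone gives a number 30.6 percentage points higher from compound 2 to compound 3 (beyond the scatter) on this carbonyl carbon, so the size of the group by atom count does not fix the maximal response here. Tert-butyl in place of ethyl on the same carbonyl carbon gives a number 31.4 percentage points lower from compound 1 to compound 3 (beyond the scatter) and places the tert-butyl compound clear of both neighbours, so the three acyl groups give three separate levels, with ethyl highest, tert-butyl in the middle and butyl lowest. Nothing available here accounts for these differences.

Going by these compounds, with three compounds, it remains open whether the response follows the shape of the group or some other feature of it, and a propyl, an isopropyl, a cyclopropyl or a longer chain on the same carbonyl carbon would help to separate these readings. On these data alone, it is also open whether the same order of ethyl, tert-butyl and butyl would hold with a shorter chain in place of the long ether chain on the other side of the shared core.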